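Swapping the methoxyphenyl for a difluorophenyl on the core

The source may report more compounds than this note shows. Statements on the series, on what has been measured and on what is new or still open speak of the compounds shown alone.

Going by the values given here, compound 1 `COc1cccc(C[C@H]2COC(=O)[C@@H]2Cc2ccc(Cl)c(Cl)c2)c1` gives 34000 nM in a functional assay on HL-60 cells (Homo sapiens) for cytotoxicity, read by WST assay, with a stated time of 48 h (on this read-out lower numbers stand for an effect already at smaller amounts and higher numbers for an effect only at larger amounts of compound), the second highest of the three numbers measured so far. Compound 2 `COc1cc(C[C@H]2COC(=O)[C@@H]2Cc2ccc(Cl)c(Cl)c2)ccc1O` gives 36000 nM in this assay, and compound 3 `COc1ccc(C[C@H]2COC(=O)[C@@H]2Cc2ccc(Cl)c(Cl)c2)cc1OC` gives 24000 nM. The steps of a 1.1-fold higher number from compound 1 to compound 2 (0.02 log units; within the scatter) and a 1.4-fold lower number from compound 1 to compound 3 (0.15 log units; within the scatter) both fall within the scatter, as does a 1.5-fold lower number from compound 2 to compound 3 (0.18 log units; within the scatter). Compound 4 `O=C1OC[C@H](Cc2ccc(F)c(F)c2)[C@H]1Cc1ccc(Cl)c(Cl)c1` has not yet been measured. It differs from compound 1 by 3,4-difluorophenyl in place of 3-methoxyphenyl on a saturated chain carbon bound to a saturated ring carbon. Among the compounds with values here, no measured step exchanges the whole aryl group; the steps seen so far only add groups to the 3-methoxyphenyl ring, and none of them moves the number beyond the scatter. The step to compound 4 is therefore expected to be small, a 1.1-fold lower number from compound 1 to compound 4 (0.05 log units; within the scatter), with no clear direction. Compound 4 is estimated at 30000 nM, expected to lie between 12000 nM and 80000 nM.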

Compound 4, half-maximal effective concentration: 25000 nM
Estimate against measurement, compound 4: 1.2-fold (0.08 log units) above; low and high end bracket the measured number.
By their numbers in this assay, from the lowest: compounds 3, 4, 1 and 2 (each within the scatter of the next).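

In this assay, exchanging the whole aryl group on a saturated chain carbon bound to a saturated ring carbon, 3,4-difluorophenyl in place of 3-methoxyphenyl, gives a 1.4-fold lower number from compound 1 to compound 4 (0.13 log units; within the scatter). The earlier steps shown here only added groups to the 3-methoxyphenyl ring, whereas here the methoxy group is gone altogether and the number still stays within the scatter. Nothing available explains this result. Going by these compounds, whether an amine or a carboxylic acid on this aryl ring would move the number beyond the scatter remains open.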